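Swapping the Ring on Compound 3: Expected Cytotoxicity

The compounds below may be only part of what the source reports. "The series", "measured", "known", "first", "only" and "open" are said of these compounds alone.

Compound 1 `COC1=CC(c2cccs2)=N/C1=C\c1ccc[nH]1`: in a functional assay on PLC5 cells (Homo sapiens) for cytotoxicity, read by MTT assay (on this read-out higher numbers stand for weaker inhibition and lower numbers for stronger inhibition), compound 1 gives > 40000 nM, which is a limit of the assay rather than a number.
Compound 2 `COc1cc(-c2cc3ccccc3[nH]2)[nH]c1/C=C1/SC(=O)NC1=O`: in this assay compound 2 gives 27500 nM.
Compound 3 `COc1cc(-c2cc3ccccc3n2C(=O)OC(C)(C)C)[nH]c1/C=C1/SC(=O)NC1=O`: in this assay compound 3 gives > 40000 nM, again only a limit.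

Compound 3 thus sits at the limit of > 40000 nM in this assay, at which 2 of the 3 values shown sit, with no number of its own. Going by the values given here, the single measured step, an at least 1.4-fold higher number from compound 2 to compound 3 (0.16 log units; that floor lies within the scatter), touches a different part of the molecule and is itself bounded by a limit, so it says nothing about a ring swap. Compound 4 `COc1cc(-c2cc3ccccc3n2C(=O)OC(C)(C)C)[nH]c1/C=C1\C(=O)Nc2ccccc21` differs from compound 3 by a group of 11 heavy atoms (9 carbon, 1 nitrogen, 1 oxygen; one five-membered non-aromatic ring with 1 hetero atom, one six-membered aromatic ring of carbon only) in place of a group of 8 heavy atoms (4 carbon, 1 nitrogen, 2 oxygen, 1 sulfur; one five-membered non-aromatic ring with 2 hetero atoms), on an aromatic carbon. Among the compounds with values here, no measured pair shows this change, so neither size nor direction of its effect can be read from the data. Compound 4 is therefore expected to remain weak, a step of an at least 1.3-fold lower number from compound 3 to compound 4 (0.12 log units; that floor lies within the scatter). The estimate for compound 4 is 30000 nM, with a range from 6000 nM to 40000 nM.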

Compound 4, half-maximal inhibitory concentration: > 40000 nM
Compound 4 was reported as a limit; the forecaster's own chance of this, stated with the estimate: 50%; middle value at least 1.3-fold (0.12 log units) from the limit.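

Going by these compounds alone, compound 3 and compound 4 both rest on limits rather than numbers, so no step between them can be read: the limit of > 40000 nM in this assay, at which 3 of the 4 values shown sit. On these data alone, whether the ring swap changes cytotoxicity at all, in either direction, remains open.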